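The source may hold more compounds than are shown below. What is called first, only, known or untested is meant among the compounds shown, and "the series" means these compounds.

Measured compounds:
compound 1, `O=C(O)c1ccc(C(=O)/C(=C\c2ccc(Br)c([N+](=O)[O-])c2)SCc2ccc(Br)cc2)cc1` — 1000 nM in a functional assay on DU-145 cells (Homo sapiens) for inhibition, read by trypan blue exclusion, with a stated time of 96 h; on this read-out higher numbers stand for weaker inhibition of growth and lower numbers for stronger inhibition of growth
compound 2, `O=C(O)c1ccc(C(=O)/C(=C\c2ccc(Br)c([N+](=O)[O-])c2)SCc2ccc(Cl)cc2)cc1` — < 1000 nM in this assay

For the measured compounds named here, compound 1 is the only compound of the pair with a definite number in this assay. For compound 2 the assay gives only a limit, (the limit of < 1000 nM in this assay, at which 1 of the 2 values shown sits), so no number is known for it. Going by the values given here, the one measured step, a number no higher from compound 1 to compound 2 (the limit leaves the size open), is therefore open in size and concerns only the benzyl ring of the shared core, chloro in place of bromo on an aromatic carbon.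

Compound 3, `CSc1ccc(/C=C(/SCc2ccc(Br)cc2)C(=O)c2ccc(C(=O)O)cc2)cc1`, is not yet measured. Against compound 1 it carries 4-(methylsulfanyl)phenyl in place of 4-bromo-3-nitrophenyl on a double-bonded chain carbon bound to a double-bonded chain carbon. Among the compounds with values here, the measured step touches a different part of the core and does not bear on this change; no measured step does. Within the data shown here, nothing among the measured compounds fixes the direction or size of this change, so the expectation is kept wide. The expected step is no change at the digits printed from compound 1 to compound 3 (within the scatter), anchored on compound 1. Compound 3 is expected to give about 1000 nM in this assay, within roughly 200 nM to 5000 nM.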

Compound 3, concentration for 50% growth inhibition: 10000 nM
The estimate for compound 3 lay 10-fold (1.00 log units) below the measured number; the measured number lies above the stated range.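

The aryl group on the double-bonded chain carbon bound to a double-bonded chain carbon is not a silent position: in this assay, 4-(methylsulfanyl)phenyl in place of 4-bromo-3-nitrophenyl gives a 10-fold higher number from compound 1 to compound 3 (1.00 log units; beyond the scatter) and this step lies beyond the scatter. For the compounds shown here, the earlier pair touched only the benzyl ring, so this is the first change with a readable size, and it runs toward weaker inhibition of growth, on this single pair. Nothing at hand ties the step to any one feature of the exchange.

As far as these compounds go, whether the step belongs to the loss of the bromine, the loss of the nitro group or the arrival of the methylsulfanyl group stays open, and a plain phenyl, a bromophenyl, a nitrophenyl or an aminophenyl on this carbon would help to separate these. The value of compound 2 is a limit, so the step to it cannot be read and the benzyl ring remains without a sized change.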